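Swapping 2-chlorophenyl for 3-methylphenyl on the shared core

The source may report more compounds than this note shows. Statements on the series, on what has been measured and on what is new or still open speak of the compounds shown alone.

In a physicochemical assay for solubility, in phosphate buffer, at pH 7.4 (a higher number here means a more soluble compound, a lower number a less soluble compound), compound 1 (`CCOC(=O)c1c(-c2ccc(C(F)(F)F)cc2)[nH]c2cccc(OC)c2c1=O`) gives 22000 nM and compound 2 (`CCOC(=O)c1c(-c2ccc(C(C)(C)C)cc2)[nH]c2cc(OC)ccc2c1=O`) gives 2000 nM as measured numbers. Compound 3 (`CCOC(=O)c1c(-c2ccccc2Cl)[nH]c2cccc(OC)c2c1=O`) is known only by the limit > 100000 nM and has no number. Of the three, compound 3 alone stands at that limit (the limit of > 100000 nM in this assay, at which 1 of the 3 values shown sits).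

Compound 4 (`CCOC(=O)c1c(-c2cccc(C)c2)[nH]c2cccc(OC)c2c1=O`) carries 3-methylphenyl in place of 2-chlorophenyl on an aromatic carbon while the rest of the molecule stays as in compound 3. For the measured compounds named here, no two measured compounds differ in one place only, so this assay offers no direct guide to this step. Going by the values given here, a downward step beyond the scatter is expected, resting on compound 1 with 22000 nM as the one measured compound that shares its core with compound 3 and gives a number. On these data alone, the estimated step is an at least 2.5-fold lower number from compound 3 to compound 4 (0.39 log units; beyond the scatter) and its true size stays open. Compound 4 is estimated at 40000 nM in this assay with an expected range (12000 nM to 100000 nM).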

Compound 4, solubility: > 100000 nM
Compound 4 was reported as a limit; the forecaster's own chance of this, stated with the estimate: 20%; middle value at least 2.5-fold (0.39 log units) from the limit.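

In this assay compound 4 gives > 100000 nM, which is a limit and not a number. For the compounds shown here, compound 3 also stands at a limit, and no step between compound 3 and compound 4 can be read: the limit of > 100000 nM in this assay, at which 2 of the 4 values shown sit. On these data alone, whether 2-chlorophenyl and 3-methylphenyl differ at all in this read-out stays open.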